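The source may hold more compounds than are shown below. What is called first, only, known or untested is meant among the compounds shown, and "the series" means these compounds.

Compound 3 `O=C1CN=C(NC[C@@H]2CCCc3cc(S(=O)(=O)c4cccc(F)c4)ccc32)N1` gives the lowest number of the three measured compounds in an assay on isolated protein for displacement of a labelled ligand from 5-hydroxytryptamine receptor 6 (Homo sapiens) (a lower number here means a stronger inhibitor, a higher number a weaker inhibitor), at 0.1 nM. Compound 1 `CNCC1CCCc2cc(S(=O)(=O)c3ccccc3)ccc21` stands nearest to it, at 0.316 nM, and compound 2 `CN(C[C@@H]1CCCc2cc(S(=O)(=O)c3cccc(F)c3)ccc21)S(N)(=O)=O` stands furthest, at 3.98 nM. Compound 4 `NC(=O)CNC[C@@H]1CCCc2cc(S(=O)(=O)c3cccc(F)c3)ccc21` has not been measured yet. It differs from compound 3 in one place: a group of 4 heavy atoms (2 carbon, 1 nitrogen, 1 oxygen; no ring) in place of a group of 6 heavy atoms (3 carbon, 2 nitrogen, 1 oxygen; one five-membered non-aromatic ring with 2 hetero atoms), on an amine nitrogen. Within the data shown here, only one measured step touches the group on this nitrogen: a 40-fold lower number from compound 2 to compound 3 (1.60 log units; beyond the scatter), which exchanged the group without a ring for the five-membered ring. That step shows how much the group on this nitrogen can matter, but it does not include the carbamoylmethyl group itself. Compound 4 keeps a secondary amine on this nitrogen, as does compound 1, which carries only a methyl there and gives 0.316 nM. On that basis compound 4 is expected to give a higher number than compound 3, with the expected step being a 5.0-fold higher number from compound 3 to compound 4 (0.70 log units; beyond the scatter). The estimate for compound 4 in this assay is 0.5 nM, within a range of 0.1 nM to 2.5 nM.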

Compound 4, inhibition constant: 0.1 nM
For compound 4 the middle estimate is 5.0-fold (0.70 log units) above the measured one; low and high end bracket the measured number.
By their numbers in this assay, from the lowest: compounds 3 and 4 (each within the scatter of the next); then compound 1; then compound 2.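

In this assay, the five-membered ring is not needed for a low number on this amine nitrogen, since the open-chain carbamoylmethyl group gives a result that matches it: no change at the digits printed from compound 3 to compound 4 (within the scatter). Among these compounds, a group without a ring can also produce the large difference earlier seen only with the ring, with a 40-fold lower number from compound 2 to compound 4 (1.60 log units; beyond the scatter). Nothing available explains why these two different groups read alike.

On these data alone, it remains open which part of the carbamoylmethyl group counts, and whether the amide is required at all; an ethyl group, a carboxylic acid or a longer chain ending in the same amide on this amine nitrogen would address that. It is also unknown whether compound 3 and compound 4 would stay alike in any test other than this binding measurement.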